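Ester Swap and Expected Liver Microsome Stability

This account rests on a few compounds, and the source may have more. Where it says the series, first, only, none or still open, it means among the compounds named here.

Compound 1, `CCCCc1nc(C(C)C)c(CC(=O)OCC(F)(F)F)c(=O)n1Cc1ccc(-c2ccccc2-c2noc(=O)[nH]2)cc1`, gives "not determined" (no result reported) in an ADME assay on microsomes from liver (Mus musculus) for metabolic stability, with a stated time of 30 min; on this read-out lower numbers stand for a less stable compound and higher numbers for a more stable compound.
Compound 2, `CCCCc1nc(C(C)C)c(CC(=O)OC2CC2)c(=O)n1Cc1ccc(-c2ccccc2-c2noc(=O)[nH]2)cc1`, gives 11.4% in this assay .

Going by the values given here, compound 2 stands as the only measured number here; compound 1 offers no result, so nothing can be compared between the two. Compound 3, `CC#CCOC(=O)Cc1c(C(C)C)nc(CCCC)n(Cc2ccc(-c3ccccc3-c3noc(=O)[nH]3)cc2)c1=O`, differs from compound 2 by but-2-yn-1-yl in place of cyclopropyl on an oxygen next to a carbonyl group. Among the compounds with values here, no measured step exists to lean on. The expected step is small: a number 3.4 percentage points lower from compound 2 to compound 3 (within the scatter), a slight drop that stays within the usual scatter. Compound 3 is estimated at 8%, with a range from 2% to 22%.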

Compound 3, percent of the compound remaining: 16.4%
For compound 3 the middle estimate is 8.4 percentage points below the measured one, within the range that was stated.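

In this assay, but-2-yn-1-yl in place of cyclopropyl on an oxygen next to a carbonyl group gives a number 5 percentage points higher from compound 2 to compound 3 (within the scatter). On this read-out, then, the open chain with its triple bond and the three-membered ring cannot be told apart at this position. No supporting measurement speaks to a cause for this result. Compound 1 has no number, so its ester cannot be compared with either of the others. From the compounds shown here alone, how an amide or a carboxylic acid in place of the ester would read remains open.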